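The source may hold more compounds than are shown below. What is called first, only, known or untested is meant among the compounds shown, and "the series" means these compounds.

The series shares one macrocyclic core and varies the aromatic substituent on its fused bicyclic ring. Compound 1 `COc1ccc2c(O[C@H]3C[C@H]4C(=O)N(C)CCCC/C=C/[C@@H]5C[C@@]5(C(=O)NS(=O)(=O)C5CC5)NC(=O)N4C3)cc(-c3nc(C4CC4)cs3)nc2c1Cl` carries a cyclopropyl-thiazolyl group, compound 2 `COc1ccc2c(O[C@H]3C[C@H]4C(=O)N(C)CCCC/C=C/[C@@H]5C[C@@]5(C(=O)NS(=O)(=O)C5(C)CC5)NC(=O)N4C3)cc(-c3cc(C(C)C)on3)nc2c1Cl` an isopropyl-isoxazolyl group, and compound 3 `COc1ccc2c(O[C@H]3C[C@H]4C(=O)N(C)CCCC/C=C/[C@@H]5C[C@@]5(C(=O)NS(=O)(=O)C5(C)CC5)NC(=O)N4C3)cc(-n3cc(C(C)C)cn3)nc2c1C` an isopropyl-pyrazolyl group on a core that also swaps chlorine for methyl. In an ADME assay on Huh-7 cells (Homo sapiens) for cytotoxicity, read by colorimetric assay (on this read-out lower numbers stand for higher toxicity in this test and higher numbers for lower toxicity in this test), compound 2 gives 75000 nM, the highest of the three numbers. Compound 1 gives 31300 nM, a step that lies beyond the usual scatter, and compound 3 gives 9610 nM, the furthest away and also beyond the scatter. Compound 4 `COc1ccc2c(O[C@H]3C[C@H]4C(=O)N(C)CCCC/C=C/[C@@H]5C[C@@]5(C(=O)NS(=O)(=O)C5(C)CC5)NC(=O)N4C3)cc(-n3cc(C(C)C)nn3)nc2c1Cl` has not yet been measured in this assay. It differs from compound 2 in one place: 4-isopropyl-1H-1,2,3-triazol-1-yl in place of 5-isopropyl-1,2-oxazol-3-yl on an aromatic carbon. For the measured compounds named here, no direct step between measured compounds covers this exchange, so the expectation rests on the whole set. Going by the values given here, compound 3, the only measured compound with a nitrogen-linked azole, gave the lowest number with 9610 nM, but it also carries the altered core, so its weight is limited. The author expects compound 4 to land somewhat lower than compound 2, by a step of a 1.9-fold lower number from compound 2 to compound 4 (0.27 log units; within the scatter), near the edge of the scatter. The estimate for compound 4 in this assay is 40000 nM, with a range from 15000 nM to 95000 nM.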

Compound 4, half-maximal cytotoxic concentration: 28500 nM
Compound 4: the middle estimate sits 1.4-fold (0.15 log units) above what was measured; the range from low to high includes it.
By their numbers in this assay, from the lowest: compound 3; then compounds 4 and 1 (each within the scatter of the next); then compound 2.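

In this assay, for the compounds shown here, putting 4-isopropyl-1H-1,2,3-triazol-1-yl in place of 5-isopropyl-1,2-oxazol-3-yl gives a 2.6-fold lower number from compound 2 to compound 4 (0.42 log units; beyond the scatter), the first step in this set that isolates this position, on an aromatic carbon next to the ring nitrogen. Both groups have the same number of heavy atoms, carry an isopropyl group and have no net charge, so the change lies in the five-membered ring itself, with its hetero atoms and its point of attachment; even this exchange of one azole for another moves the number beyond the scatter, towards higher toxicity in this test. Nothing given here explains the size or direction of the step.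

The compounds shown leave open whether the step follows the extra ring nitrogen or the attachment through nitrogen, which a carbon-linked 1,2,3-triazole bearing the same isopropyl group could separate. They also leave open how a tert-butyl group or a primary amine in place of the isopropyl group on the triazole would read in this assay.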